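Metabolic stability of N-acyl serine amides: compound 3 to 4

The source may hold more compounds than are shown below. What is called first, only, known or untested is meant among the compounds shown, and "the series" means these compounds.

Compound 1, `C=C(C)C(=O)N[C@@H](CO)C(=O)O`: in an ADME assay on microsomes from liver (Homo sapiens) for metabolic stability, with a stated time of 30 min (a higher number here means that more of the compound is left, a lower number that less of the compound is left), compound 1 gives 82%.
Compound 2, `CN(C)C(=O)N[C@@H](CO)C(=O)O`: in this assay compound 2 gives 34%.
Compound 3, `COC(=O)C(=O)N[C@@H](CO)C(=O)O`: in this assay compound 3 gives "not determined" (no result reported).
Compound 4, `O=C(N[C@@H](CO)C(=O)O)C1CC1`: not yet measured.

Among the compounds with values here, compound 3 stands nowhere on the numbers; its value in this assay was not determined, so no step to compound 4 can be computed. The change is cyclopropyl in place of methoxycarbonyl on a carbonyl carbon.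

Within the data shown here, the only measured step, a number 48 percentage points lower from compound 1 to compound 2 (beyond the scatter), also sits on the carbonyl carbon bearing the amide-type nitrogen and shows that a change there can move the read-out well beyond the scatter. Compound 4 carries cyclopropyl, a carbon-only group like the 1-methylethenyl of compound 1 rather than the dimethylamino of compound 2, so a value nearer that of compound 1 is expected. Compound 4 is estimated at 75%, within 50% to 95%.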

Compound 4, percent of the compound remaining: 26%
Compound 4: the middle estimate sits 49 percentage points above what was measured; the whole stated range lies above it.
By their numbers in this assay, from the lowest: compounds 4 and 2 (each within the scatter of the next); then compound 1.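

Cyclopropyl in place of 1-methylethenyl on a carbonyl carbon gives a number 56 percentage points lower from compound 1 to compound 4 (beyond the scatter), while cyclopropyl in place of dimethylamino gives a number 8 percentage points lower from compound 2 to compound 4 (within the scatter). A carbon-only group at this position therefore does not by itself keep the read-out high, and compound 1 stands apart from both compound 2 and compound 4. Within the data shown here, nothing measured so far bears on the reason for this.

Steps involving compound 3 cannot be read. Going by these compounds, whether isopropyl or a longer chain at this position would fall with compound 1 or with compound 2 and compound 4 remains open.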